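Adding a second methoxy to the shared core of compound 1

The compounds below may be only part of what the source reports. "The series", "measured", "known", "first", "only" and "open" are said of these compounds alone.

Measured so far:
compound 1 `COc1cccc2c1OCN(c1ccc3oc(-c4ccccc4)cc(=O)c3c1)C2` gives 67.8%
compound 2 `Cc1cccc2c1OCN(c1ccc3oc(-c4ccccc4)cc(=O)c3c1)C2` gives 72.4%
compound 3 `O=c1cc(-c2ccccc2)oc2ccc(N3COc4ccccc4C3)cc12` gives 68.5%

Of the compounds shown here, three have been tested in a functional assay on MCF7 cells (Homo sapiens) for inhibition, read by MTT assay, with a stated time of 48 h, tested at 30 ug/mL (a higher number here means more inhibition of growth at the concentration tested, a lower number less inhibition of growth), and they sit close together. Compound 1 has the lowest of the three numbers; the nearest is compound 3, with a number 0.7 percentage points higher from compound 1 to compound 3 (within the scatter), and the furthest is compound 2, with a number 4.6 percentage points higher from compound 1 to compound 2 (within the scatter). Neither step leaves the scatter, and between compound 2 and compound 3 the difference is a number 3.9 percentage points lower from compound 2 to compound 3 (within the scatter).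

Compound 4 `COc1cc2c(c(OC)c1)OCN(c1ccc3oc(-c4ccccc4)cc(=O)c3c1)C2` has not yet been measured in this assay. It differs from compound 1 in one place: methoxy in place of hydrogen on an aromatic carbon. For the measured compounds named here, the step that bears most directly on this change is the one from compound 1 to compound 3, where removing a methoxy gave a number 0.7 percentage points higher from compound 1 to compound 3 (within the scatter), and the exchange of that methoxy for methyl from compound 1 to compound 2 gave a number 4.6 percentage points higher from compound 1 to compound 2 (within the scatter). Both were within the scatter, so no step beyond the scatter is expected in this assay for the added methoxy of compound 4.

The estimate for compound 4 is therefore 68%, with a range from 56% to 80%, corresponding to an expected a number 0.2 percentage points higher from compound 1 to compound 4 (within the scatter).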

Compound 4, percent growth inhibition at one concentration: 79%
The estimate for compound 4 lay 11 percentage points below the measured number; the range from low to high includes it.
By their numbers in this assay, from the lowest: compounds 1, 3, 2 and 4 (each within the scatter of the next, the first and the last beyond it).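

In this assay, methoxy in place of hydrogen on an aromatic carbon, meta to the existing methoxy group and para to a fused ring, gave a number 11.2 percentage points higher from compound 1 to compound 4 (beyond the scatter). For the compounds shown here, this is the first step to leave the scatter, and its size is modest. The earlier steps changed only the group at the site of the existing methoxy and stayed within the scatter, whereas this result shows that a second carbon of the same aromatic ring can carry a substituent with a measurable gain in growth inhibition at the tested concentration, though no measurement of any property of these compounds accompanies the step.

The compounds shown leave open whether a hydroxyl, an amine, a chlorine or a longer chain such as ethoxy at this carbon would give a step of similar size, or whether it is particular to methoxy. They also leave open whether the gain depends on the first methoxy group, as no compound shown carries the new methoxy with hydrogen or methyl in that first place.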